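Three Aryl Groups Measured, a Fourth Awaited

A few compounds are considered here, and "the series" means these few. Any claim that something is new, unique, unknown or untested is made for them only; others in the source may bear on it.

In a functional assay (aorta) with Oryctolagus cuniculus as the target (on this read-out lower numbers stand for stronger inhibition and higher numbers for weaker inhibition), the three measured compounds gave these numbers:

compound 1 `CCO/C(O)=C1\C(C)=NC(C)=C(C(=O)OCCCN2C(=O)c3ccccc3S2(=O)=O)C1c1cccc([N+](=O)[O-])c1`: 1.9 nM
compound 2 `CCO/C(O)=C1\C(C)=NC(C)=C(C(=O)OCCCN2C(=O)c3ccccc3S2(=O)=O)C1c1ccccc1[N+](=O)[O-]`: 2.6 nM
compound 3 `CCO/C(O)=C1\C(C)=NC(C)=C(C(=O)OCCCN2C(=O)c3ccccc3S2(=O)=O)C1c1cccc(Cl)c1Cl`: 1.8 nM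

Compound 3 holds the lowest of the three numbers, yet every comparison is small: a 1.1-fold lower number from compound 1 to compound 3 (0.02 log units; within the scatter) and a 1.4-fold lower number from compound 2 to compound 3 (0.16 log units; within the scatter) both lie within the scatter, as does a 1.4-fold higher number from compound 1 to compound 2 (0.14 log units; within the scatter). Compound 4 `CCO/C(O)=C1\C(C)=NC(C)=C(C(=O)OCCCN2C(=O)c3ccccc3S2(=O)=O)C1c1ccccc1C(F)(F)F` is reached by 2-(trifluoromethyl)phenyl in place of 2,3-dichlorophenyl on a saturated ring carbon. All three measured steps were exchanges of the aryl group at this same position, and none moved this assay beyond the scatter; on that basis the step from compound 3 to compound 4 is expected to be a 1.4-fold higher number from compound 3 to compound 4 (0.14 log units; within the scatter), with no direction beyond the scatter. Compound 4 is therefore estimated at 2.5 nM in this assay, with a range from 1 nM to 6 nM.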

Compound 4, half-maximal inhibitory concentration: 0.8 nM
Estimate against measurement, compound 4: 3.1-fold (0.49 log units) above; the measured number lies below the stated range.
By their numbers in this assay, from the lowest: compound 4; then compounds 3, 1 and 2 (each within the scatter of the next).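

At this position on a saturated ring carbon, 2-(trifluoromethyl)phenyl is the first aryl group shown to move this assay beyond the scatter, with a 2.3-fold lower number from compound 3 to compound 4 (0.35 log units; beyond the scatter) and a 2.4-fold lower number from compound 1 to compound 4 (0.38 log units; beyond the scatter) and, for trifluoromethyl in place of nitro on an aromatic carbon, a 3.3-fold lower number from compound 2 to compound 4 (0.51 log units; beyond the scatter). The aryl group here can therefore shift the number, though only modestly, whereas compounds 1, 2 and 3 stay within the scatter of one another. No evidence is available that accounts for this shift.

The compounds shown leave open whether 3-(trifluoromethyl)phenyl would match compound 4. They also leave open how a phenyl carrying a nitrile or a methoxy group would compare.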